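Cyano to Methoxy on the Cinnamamide Aryl Ring

A few compounds are considered here, and "the series" means these few. Any claim that something is new, unique, unknown or untested is made for them only; others in the source may bear on it.

Measured compounds in a functional assay on MCF7 cells (Homo sapiens) for cytotoxicity, read by MTT assay, with a stated time of 72 h; a lower number here means a stronger inhibitor, a higher number a weaker inhibitor:
compound 1, `COc1cc2ncnc(Nc3ccc(F)c(Cl)c3)c2cc1NC(=O)/C=C/c1ccc(C#N)cc1`: "not active" (no number reported)
compound 2, `COc1ccc(/C=C/C(=O)Nc2cc3c(Nc4ccc(F)c(Cl)c4)ncnc3cc2O[C@H]2CCOC2)c(OC)c1OC`: 4650 nM
compound 3, `N#Cc1ccc(/C=C/C(=O)Nc2cc3c(Nc4ccc(F)c(Cl)c4)ncnc3cc2O[C@H]2CCOC2)cc1`: 9830 nM

Compound 1 stands apart from the other two: in this assay compound 1 is reported as "not active" (no number reported), so no number places it against compound 2 or compound 3. Among the measured compounds shown here, compound 2 and compound 3 share a core with compound 1 but carry a different ether on it, and they are the only pair with a step: a 2.1-fold higher number from compound 2 to compound 3 (0.33 log units; beyond the scatter).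

Compound 4, `COc1ccc(/C=C/C(=O)Nc2cc3c(Nc4ccc(F)c(Cl)c4)ncnc3cc2OC)cc1`, keeps the core of compound 1 and changes only the aryl ring of the chain: methoxy in place of cyano on an aromatic carbon. The step from compound 2 to compound 3 is the one that bears on this change, since it also exchanges a methoxy-bearing aryl for the cyano-bearing one, though in the other direction and with three methoxy groups rather than one. That step was modest, and going from cyano back toward methoxy it points, if anything, toward a lower number in this assay. Because compound 1 gives "not active" (no number reported) and compound 3 gives 9830 nM, compound 4 is expected to remain weak, and a reported number may not be obtained at all. Compound 4 is estimated at 15000 nM, in a range from 4000 nM to 60000 nM.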

Compound 4, half-maximal inhibitory concentration: "not active" (no number reported)
Compound 4 has no reported number here; there is nothing to compare the estimate with.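

In this assay compound 4 gives "not active" (no number reported) and compound 1 gives "not active" (no number reported), so no step can be read between them. The compounds shown leave open whether methoxy in place of cyano changes the activity at all on the core of compound 1. Nothing shown offers an explanation for this result.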